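This account rests on a few compounds, and the source may have more. Where it says the series, first, only, none or still open, it means among the compounds named here.

Measured in a functional assay on RKO cells (Homo sapiens) for inhibition, read by MTT assay, with a stated time of 48 h; a higher number here means a weaker inhibitor, a lower number a stronger inhibitor:

compound 1 `COc1ccc(N(C)c2nc(C)nc3ccccc23)cc1OCCC[Se]C#N` gives 799 nM
compound 2 `COc1ccc(N(C)c2nc(C)nc3ccccc23)cc1OCCCC[Se]C#N` gives 1360 nM
compound 3 `COc1ccc(N(C)c2nc(C)nc3ccccc23)cc1C(=O)OCCCCCC[Se]C#N` gives 1990 nM

Compound 2 and compound 1 share a core and differ by one change, (a group of 3 heavy atoms (1 carbon, 1 nitrogen, 1 selenium; no ring) in place of a group of 4 heavy atoms (2 carbon, 1 nitrogen, 1 selenium; no ring), on a saturated chain carbon, three bonds along the chain from an oxygen on an aromatic ring). That change made a step of a 1.7-fold lower number from compound 2 to compound 1 (0.23 log units; within the scatter). Compound 3 carries a different core; the difference between the cores of compound 2 and compound 3 is not broken down here, and their two values lie within the scatter of one another, as do those of compound 3 and compound 2 against compound 1 only in the one direction told above.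

Compound 4 `COc1ccc(N(C)c2nc(C)nc3ccccc23)cc1C(=O)OCCCCC[Se]C#N` has not yet been measured in this assay. It stands to compound 3 as compound 1 stands to compound 2: a group of 3 heavy atoms (1 carbon, 1 nitrogen, 1 selenium; no ring) in place of a group of 4 heavy atoms (2 carbon, 1 nitrogen, 1 selenium; no ring), on a saturated chain carbon, five bonds along the chain from an oxygen next to a carbonyl group. The place differs, five bonds along the chain from an oxygen next to a carbonyl group rather than three bonds along the chain from an oxygen on an aromatic ring, so this is the same kind of change, not the same change. For compound 4 a step of a 1.4-fold lower number from compound 3 to compound 4 (0.15 log units; within the scatter) is expected, resting on the step of a 1.7-fold lower number from compound 2 to compound 1 (0.23 log units; within the scatter) made by the same kind of change. Compound 4 is estimated at 1400 nM, between 600 nM and 3500 nM.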

Compound 4, half-maximal inhibitory concentration: 356 nM
Compound 4: the middle estimate sits 3.9-fold (0.59 log units) above what was measured; measured number below the stated range.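

In this assay, the group of 3 heavy atoms in place of the group of 4 heavy atoms, five bonds along the chain from an oxygen next to a carbonyl group, gives a 5.6-fold lower number from compound 3 to compound 4 (0.75 log units; beyond the scatter). The size of this step does not carry over from one core to the other: the same change on two cores in this assay, a 1.7-fold lower number (0.23 log units; within the scatter) from compound 2 to compound 1 and a 5.6-fold lower number (0.75 log units; beyond the scatter) from compound 3 to compound 4, 3.3-fold (0.52 log units) apart, beyond the scatter of two such steps. Among these compounds, with only two pairs, the core and the place of the change vary together (five bonds along the chain from an oxygen next to a carbonyl group, against three bonds along the chain from an oxygen on an aromatic ring), so these notes show that the step is not transferable in size but not which of the two differences sets it, or why.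

Still open, from the compounds shown here alone, is how a shorter or longer chain behaves on each core, and so whether either step belongs to a steady trend with chain length. Also open, going by these compounds, is whether an amine or a carboxylic acid at the chain end, in place of the selenium-bearing nitrile group, retains any inhibition of these cells.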